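Swapping methoxy for dimethylamino on the shared core

This account rests on a few compounds, and the source may have more. Where it says the series, first, only, none or still open, it means among the compounds named here.

Of the compounds shown here, three built on the same core have been tested in a functional assay on K562 cells (Homo sapiens), read by MTT assay, with a stated time of 72 h; on this read-out lower numbers stand for stronger inhibition and higher numbers for weaker inhibition. Compound 1 `COc1ncnc2c1c(-c1ccsc1)cn2[C@@H]1O[C@H](CO)[C@@H](O)[C@H]1O` gives 3450 nM in this assay. Compound 2 `CN(C)c1ncnc2c1c(-c1ccsc1)cn2[C@@H]1O[C@H](CO)[C@@H](O)[C@H]1O` differs from compound 1 by an at least 5.7-fold higher number from compound 1 to compound 2 (0.76 log units; beyond the scatter). Compound 2 reaches only the limit of the assay, reported as > 20000 nM, so its true number is not known (the limit of > 20000 nM in this assay, at which 1 of the 3 values shown sits). Compound 3 `COc1ncnc2c1c(-c1ccoc1)cn2[C@@H]1O[C@H](CO)[C@@H](O)[C@H]1O` gives 2820 nM in this assay, the lowest of the two numbers measured, with compound 1 nearest at a 1.2-fold lower number from compound 1 to compound 3 (0.09 log units; within the scatter).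

Compound 4 `CN(C)c1ncnc2c1c(-c1ccoc1)cn2[C@@H]1O[C@H](CO)[C@@H](O)[C@H]1O` is the still unmeasured partner of compound 3, with the change (dimethylamino in place of methoxy on an aromatic carbon). Within the data shown here, the one measured step that bears on this change is that from compound 1 to compound 2, which gave an at least 5.7-fold higher number from compound 1 to compound 2 (0.76 log units; beyond the scatter) and ended at the limit of the assay. The same change on compound 3 is therefore expected to raise the number well beyond the scatter, and most likely past the limit again, giving an estimated step of an 8.9-fold higher number from compound 3 to compound 4 (0.95 log units; beyond the scatter). For compound 4 the expected value in this assay is estimated at 25000 nM, within a range of 10000 nM to 60000 nM.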

Compound 4, half-maximal inhibitory concentration: 14900 nM
Compound 4: the middle estimate sits 1.7-fold (0.22 log units) above what was measured; measured number inside the range.
By their numbers in this assay, from the lowest: compounds 3 and 1 (each within the scatter of the next); then compound 4. At a limit, above all of these: compound 2.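

In this assay, dimethylamino in place of methoxy on this aromatic carbon gives a 5.3-fold higher number from compound 3 to compound 4 (0.72 log units; beyond the scatter), so the weakening seen with thiophen-3-yl also appears with furan-3-yl, this time as a full measured number. The change therefore raises the number on both cores, but the two steps cannot be ranked by size: the same change on two cores in this assay, an at least 5.7-fold higher number (0.76 log units; beyond the scatter) from compound 1 to compound 2 and a 5.3-fold higher number (0.72 log units; beyond the scatter) from compound 3 to compound 4; the limit leaves it open whether they differ Between the two dimethylamino compounds the step is an at least 1.3-fold lower number from compound 2 to compound 4 (0.12 log units; that floor lies within the scatter), and this does not establish a real difference between furan-3-yl and thiophen-3-yl: the same change on two cores in this assay, a 1.2-fold lower number (0.09 log units; within the scatter) from compound 1 to compound 3 and an at least 1.3-fold lower number (0.12 log units; that floor lies within the scatter) from compound 2 to compound 4; the limit leaves it open whether they differ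

Going by these compounds, it remains open whether a smaller amine such as methylamino, or a longer ether such as ethoxy, would read closer to methoxy or to dimethylamino at this position. The reason for the rise also stays open: no property of either group is measured here.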